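Compound 1 to compound 3: swapping phenoxymethyl

This account rests on a few compounds, and the source may have more. Where it says the series, first, only, none or still open, it means among the compounds named here.

compound 1 `COc1ccc2[nH]c(C(=O)N3CC(=O)N(Cc4ccccc4)[C@@H](COc4ccccc4)C3)cc2c1`: 0.65 h
compound 2 `COc1ccc2[nH]c(C(=O)N3CC(=O)N(Cc4ccc[nH]4)[C@@H](Cc4ccccc4)C3)cc2c1`: 0.267 h

In an ADME assay on microsomes from liver (Homo sapiens) for metabolic stability, with a stated time of 30 min, tested at 1 uM (a lower number here means that the compound disappears faster, a higher number that the compound lasts longer), compound 1 stands highest of the two measured compounds, and compound 2 lies lower by more than the usual scatter. The step followed here leads to compound 3 `COc1ccc2[nH]c(C(=O)N3CC(=O)N(Cc4ccccc4)[C@@H](N4[C@H](C)CCC[C@@H]4C)C3)cc2c1`, with 2,6-dimethylpiperidin-1-yl in place of phenoxymethyl on a saturated ring carbon. Among the measured compounds shown here, the series holds no measured pair that differs in one place, so nothing shows directly what this exchange does in this assay. For the measured compounds named here, the only anchors are compound 1 at 0.65 h and compound 2 at 0.267 h, and the cautious expectation is a value inside that span. That means a small downward step, probably not beyond the scatter, and the direction is held loosely. The expected change is a 1.6-fold lower number from compound 1 to compound 3 (0.21 log units; within the scatter). For compound 3 the estimated half-life is 0.4 h, with an expected range of 0.15 h to 1 h.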

Compound 3, half-life: 0.112 h
Estimate against measurement, compound 3: 3.6-fold (0.55 log units) above; the whole stated range lies above it.
By their numbers in this assay, from the lowest: compound 3; then compound 2; then compound 1.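

This exchange gives the series its first pair differing in one place, and in this assay it shows that the half-life responds to the group on this saturated ring carbon: 2,6-dimethylpiperidin-1-yl in place of phenoxymethyl gives a 5.8-fold lower number from compound 1 to compound 3 (0.76 log units; beyond the scatter). The counts of heavy atoms, hydrogen-bond donors and hydrogen-bond acceptors match on the two sides and neither group carries a net charge, so matching these counts does not preserve the half-life at this position. What does differ is the ring type, with a six-membered aromatic ring of carbon only replaced by a six-membered non-aromatic ring with a hetero atom, together with oxygen giving way to nitrogen and the arrival of defined stereocentres, and nothing measured here bears on which of these matters.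

A single step cannot separate these differences from one another, nor show what the methyl groups or their stereochemistry contribute. On these data alone, whether an unsubstituted piperidin-1-yl, a morpholin-4-yl or a benzyloxymethyl group at this position would stay close to compound 1 at 0.65 h in this assay remains open.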